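A Trifluoromethyl Benzyl Ether on a Shared Core

The compounds below may be only part of what the source reports. "The series", "measured", "known", "first", "only" and "open" are said of these compounds alone.

Compound 1, `COc1cc(OC)c(-c2coc3cc(OCc4ccccc4)ccc3c2=O)cc1OC`: 2330 nM
Compound 2, `COc1cc(OC)c(-c2coc3cc(OCc4cccc(F)c4)ccc3c2=O)cc1OC`: 2440 nM

Both numbers come from a functional assay on B16 cells (Mus musculus) for antiproliferative activity, read by MTT assay, with a stated time of 24 h; a lower number here means a stronger inhibitor, a higher number a weaker inhibitor. For the measured compounds named here, compound 2 and compound 1 cannot be told apart on these numbers: the only step between them, a 1.0-fold higher number from compound 1 to compound 2 (0.02 log units; within the scatter), lies within the scatter. So compound 2 stands on level ground with the one other compound measured.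

Compound 3 is `COc1cc(OC)c(-c2coc3cc(OCc4ccc(C(F)(F)F)cc4)ccc3c2=O)cc1OC`. It differs from compound 2 in one place: 4-(trifluoromethyl)phenyl in place of 3-fluorophenyl on a saturated chain carbon bound to an oxygen on an aromatic ring. The benzyl ether attached to the shared core is kept; only the group on its ring changes.

Going by the values given here, only one measured step bears on this, a 1.0-fold higher number from compound 1 to compound 2 (0.02 log units; within the scatter), which showed that putting a fluorine on that ring left the number where it was. Nothing measured tells how a 4-(trifluoromethyl)phenyl in this position behaves, and that is a larger swap than a single fluorine for hydrogen. The expectation is therefore a step of about a 1.1-fold higher number from compound 2 to compound 3 (0.06 log units; within the scatter), a change not clearly beyond the scatter, with wide uncertainty. Compound 3 is estimated at 2800 nM in this assay, expected to fall between 1200 nM and 6500 nM.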

Compound 3, half-maximal inhibitory concentration: 5400 nM
Compound 3: the middle estimate sits 1.9-fold (0.29 log units) below what was measured; the measured number falls inside the stated range.
By their numbers in this assay, from the lowest: compounds 1 and 2 (each within the scatter of the next); then compound 3.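

The earlier compounds shown here made this benzyl ring look indifferent to what it carries, but a change here can move the number in this assay after all: 4-(trifluoromethyl)phenyl in place of 3-fluorophenyl gives a 2.2-fold higher number from compound 2 to compound 3 (0.35 log units; beyond the scatter) and marks a modest loss of inhibition. The same holds against the unsubstituted ring, where trifluoromethyl in place of hydrogen gives a 2.3-fold higher number from compound 1 to compound 3 (0.37 log units; beyond the scatter) and is likewise modest but beyond the scatter, so a substituent on this ring is not always tolerated without cost. Nothing available here explains why this group weakens inhibition when a single fluorine did not.

Compound 2 and compound 3 differ both in the group and in where it sits on the ring, so the compounds shown cannot separate those two changes. They also leave open how this position would respond to a group of another kind on the same ring, such as a methoxy group, an amine or a carboxylic acid.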